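The source may report more compounds than this note shows. Statements on the series, on what has been measured and on what is new or still open speak of the compounds shown alone.

Measured compounds:
- compound 1, `O=[N+]([O-])c1ccc(S(=O)(=O)Nc2cnccn2)cc1`: > 256000 nM
- compound 2, `O=S(=O)(Nc1cnccn1)c1ccc(Cl)cc1`: "not determined" (no result reported)
- compound 3, `O=S(=O)(Nc1cnccn1)c1ccccc1`: "not determined" (no result reported)

In an ADME assay on J774 cells (Mus musculus) for cytotoxicity, read by resazurin assay, with a stated time of 24 h (a lower number here means a stronger inhibitor, a higher number a weaker inhibitor), compound 1 returns only a limit, > 256000 nM, and not a number. Among the measured compounds shown here, compound 2 has no result in this assay, and compound 3 likewise has no result in this assay, so the series holds a single reading and no step between measured compounds. Compound 1 therefore stands at the upper edge of what the assay reports, as the limit of > 256000 nM in this assay, at which 1 of the 3 values shown sits, shows, and nothing here places it relative to another compound.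

The next compound, compound 4, `Cc1cc(NS(=O)(=O)c2ccc([N+](=O)[O-])cc2)n[nH]1`, changes the amine side of the sulfonamide: 5-methyl-1H-pyrazol-3-yl in place of pyrazin-2-yl on a sulfonamide nitrogen. The sulfonyl arene and its nitro group are kept.

For the measured compounds named here, with no measured step to lean on, the expectation for the step from compound 1 to compound 4 in this assay is no shift beyond the scatter, and that step is estimated as a step that the limit leaves unreadable from compound 1 to compound 4. Compound 4 is expected to return about 300000 nM in this assay, within 100000 nM to 1000000 nM, and most probably again only as a limit rather than a number, because compound 1 itself sits at the limit of > 256000 nM in this assay, at which 1 of the 3 values shown sits.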

Compound 4, half-maximal inhibitory concentration: > 256000 nM
Compound 4 was reported as a limit; the forecaster's own chance of this, stated with the estimate: 80%; the middle value is on the limit's open side.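

In this assay compound 4 gives > 256000 nM, a limit and not a number. Compound 1 also stands as a limit, so no step can be read from compound 1 to compound 4. What the compounds shown leave open is whether 5-methyl-1H-pyrazol-3-yl in place of pyrazin-2-yl on a sulfonamide nitrogen shifts the reading in this assay at all.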